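Methyl on the hydroxy-bearing ring carbon: compound 3 to 4

A few compounds are considered here, and "the series" means these few. Any claim that something is new, unique, unknown or untested is made for them only; others in the source may bear on it.

Measured compounds:
- compound 1, `C[C@]1(O)C[C@](c2ccc(OC(F)(F)F)cc2)([C@H](O)c2ccccn2)C1`, 1510 nM
- compound 2, `C[C@]1(O)C[C@@](c2ccc(C(F)(F)F)cc2)([C@H](O)c2ccccn2)C1`, 840 nM
- compound 3, `O[C@H](c1ccccn1)[C@]1(c2ccc(C(F)(F)F)cc2)C[C@H](O)C1`, 2240 nM

All three were run in an assay on HEK293 cells for antagonist activity at transient receptor potential cation channel subfamily V member 3 (Homo sapiens), read by FLIPR and calcium flux; on this read-out lower numbers stand for stronger inhibition and higher numbers for weaker inhibition. Compound 3 gives the highest of the three numbers. Its nearest neighbour is compound 1; the gap between them lies within the scatter, so nothing can be said of their order. Against compound 2 the gap is beyond the scatter, and compound 3 gives the higher number there.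

Compound 4, `C[C@]1(O)C[C@](c2ccc(C(F)(F)F)cc2)([C@H](O)c2ccccn2)C1`, is not yet measured. It differs from compound 3 by methyl in place of hydrogen on a saturated ring carbon. Going by the values given here, no step between measured compounds shows this change on its own, so the direction has to be read from the wider series. Both compounds that carry the methyl at this place sit at lower numbers than compound 3: in this assay compound 1 gives 1510 nM and compound 2 gives 840 nM. A step toward lower numbers, roughly at the edge of the scatter, is therefore the expectation for compound 4; the step from compound 3 is expected to be a 1.9-fold lower number from compound 3 to compound 4 (0.27 log units; within the scatter). Compound 4 is estimated at 1200 nM, with a range from 500 nM to 3000 nM.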

Compound 4, antagonist equilibrium constant: 4790 nM
Compound 4: middle estimate off by 4.0-fold (0.60 log units), on the low side; the measured number lies above the stated range.
By their numbers in this assay, from the lowest: compounds 2, 1 and 3 (each within the scatter of the next, the first and the last beyond it); then compound 4.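

In this assay, methyl in place of hydrogen on this saturated ring carbon, read on its own, gives a 2.1-fold higher number from compound 3 to compound 4 (0.33 log units; beyond the scatter), so the methyl alone does not account for the lower numbers of compound 1 and compound 2. The largest of the new steps, a 5.7-fold higher number from compound 2 to compound 4 (0.76 log units; beyond the scatter), can be assigned to stereochemistry alone, with the methyl present on both sides, because of one fact: the fact that compounds 2 and 4 differ only in the configuration as drawn. The aromatic substituent also counts at this configuration, with trifluoromethyl in place of trifluoromethoxy giving a 3.2-fold higher number from compound 1 to compound 4 (0.50 log units; beyond the scatter).

From the compounds shown here alone, the methyl step can be read in one configuration only, so its direction and size in the configuration of compound 2 stay open, as does the separate contribution of each of the two differing stereo elements. Going by these compounds, how an ethyl group, a longer chain or an amine would behave on this saturated ring carbon also stays open.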